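Fluoro in Place of Methyl: What to Expect for Compound 4

This account rests on a few compounds, and the source may have more. Where it says the series, first, only, none or still open, it means among the compounds named here.

Of the compounds shown here, three have been measured in a functional assay on A-375 cells (Homo sapiens) for antiproliferative activity, read by MTT assay, with a stated time of 24 h, tested at 0.02 ug/mL; a higher number here means a stronger effect of the compound at the concentration tested, a lower number a weaker effect. Compound 1 `Cc1ccc2nc(C(=O)Nc3c(F)cc(-c4cccc(F)c4)cc3F)c(C)c(O)c2c1` gives 0.38%, compound 2 `COc1ccc2nc(C(=O)Nc3ccc(-c4ccccc4)cc3)c(C)c(O)c2c1` gives 0.56%, and compound 3 `Cc1ccc2nc(C(=O)Nc3c(F)cc(-c4cccc(F)c4)cc3F)c(C)c(C(=O)O)c2c1` gives 0.02%. Compound 3 has the smallest of the three numbers, yet its gaps to compound 1 and compound 2 are both within the usual scatter of this assay, so the three values cannot be told apart. Among the compounds with values here, the one step between compounds that differ in a single place, a number 0.4 percentage points lower from compound 1 to compound 3 (within the scatter), is likewise within the scatter.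

Compound 4 `Cc1c(C(=O)Nc2c(F)cc(-c3cccc(F)c3)cc2F)nc2ccc(F)cc2c1C(=O)O` has not been measured. It differs from compound 3 in one place: fluoro in place of methyl on an aromatic carbon. Within the data shown here, no measured step concerns a change of this kind on the fused ring; the only measured step, carboxy in place of hydroxy on an aromatic carbon, moved the number by an amount within the scatter. All three measured values sit close to zero, and nothing in the data points to compound 4 behaving otherwise. Compound 4 is therefore expected to show a change of a number 0.3 percentage points higher from compound 3 to compound 4 (within the scatter), nothing beyond the scatter. The estimate for compound 4 is 0.3%, with a range from -4% to 5%.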

Compound 4, a percentage reported as inhibition, at one concentration (the size of the read-out at that concentration, not a potency): -0.22%
Estimate against measurement, compound 4: 0.5 percentage points above; the range from low to high includes it.
By their numbers in this assay, from the lowest: compounds 4, 3, 1 and 2 (each within the scatter of the next).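

In this assay, within the data shown here, fluoro in place of methyl, on an aromatic carbon of a six-membered aromatic ring of carbon only, gives a number 0.2 percentage points lower from compound 3 to compound 4 (within the scatter) and so provides the first reading of a single change at this position. With the carboxy group held constant, neither methyl nor fluoro at this position separates compound 3 from compound 4, and the step adds a second single-place change that stays within the scatter, at a different site from the earlier exchange of hydroxy for carboxy. The compounds shown offer no explanation for this result.

All four numbers lie close to zero at the one concentration shown, so this pair leaves open whether methyl and fluoro would differ under conditions where the compounds give a larger read-out. From the compounds shown here alone, it also remains open whether a different group at this position, such as an amine or a longer chain like propyl, would move the number in this assay beyond the scatter.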